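This account rests on a few compounds, and the source may have more. Where it says the series, first, only, none or still open, it means among the compounds named here.

Measured compounds in a functional assay on NCI-H1975 cells (Homo sapiens) for antiproliferative activity, read by MTT assay, with a stated time of 72 h; on this read-out lower numbers stand for stronger inhibition and higher numbers for weaker inhibition:
- compound 1 `COc1cc(F)c(NC(=O)c2ccccn2)cc1Nc1nccc(-c2cn(C)c3ccccc23)n1`; in this assay compound 1 gives 16500 nM
- compound 2 `COc1cc(F)c(NC(=O)c2ncccn2)cc1Nc1nccc(-c2cn(C)c3ccccc23)n1`; in this assay compound 2 gives 13500 nM

On the numbers shown, compound 2 holds the lowest of the two values, with compound 1 nearest; the step of a 1.2-fold lower number from compound 1 to compound 2 (0.09 log units; within the scatter) lies within the scatter, so no order between the two is claimed.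

The next compound, compound 3 `COc1cc(F)c(NC(=O)c2nccn2C)cc1Nc1nccc(-c2cn(C)c3ccccc23)n1`, is not yet measured. Its difference from compound 2 is 1-methyl-1H-imidazol-2-yl in place of pyrimidin-2-yl on a carbonyl carbon. Among the measured compounds shown here, only one measured step touches the same carbonyl carbon, namely a 1.2-fold lower number from compound 1 to compound 2 (0.09 log units; within the scatter), and that step stayed within the scatter. For the measured compounds named here, compound 3 brings a five-membered aromatic ring with 2 hetero atoms to the place where compound 2 carries a six-membered one, a change for which no measured pair exists, so the expectation rests on the single neighbouring step alone. No step beyond the scatter is therefore expected in this assay; the step of a 1.1-fold lower number from compound 2 to compound 3 (0.05 log units; within the scatter) is the expected size. The estimate for compound 3 is 12000 nM, with a range from 4000 nM to 40000 nM, reflecting the thin basis.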

Compound 3, half-maximal inhibitory concentration: 10600 nM
Compound 3: the middle estimate sits 1.1-fold (0.05 log units) above what was measured, within the range that was stated.
By their numbers in this assay, from the lowest: compounds 3, 2 and 1 (each within the scatter of the next).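

The ring-size change on this carbonyl carbon, from a six-membered aromatic ring with 2 hetero atoms to a five-membered one, gives a 1.3-fold lower number from compound 2 to compound 3 (0.11 log units; within the scatter) in this assay and so adds a case that compound 1 and compound 2 could not show: the ring itself can change at an equal count of heavy atoms without a step beyond the scatter. The wider replacement of pyridin-2-yl by 1-methyl-1H-imidazol-2-yl gives a 1.6-fold lower number from compound 1 to compound 3 (0.19 log units; within the scatter) and also stays within the scatter, so compound 1 at 16500 nM and compound 3 at 10600 nM establish no order among these aromatic groups on the carbonyl carbon. Nothing at hand explains this flat response, and no supporting measurement bears on it.

Still open, on these data alone, is whether any group on this carbonyl carbon can produce a step beyond the scatter in this assay, for example a dimethylaminomethyl chain, a morpholine ring or a carboxylic acid in place of the aromatic ring. Also open, as far as these compounds go, is whether the same flat response would hold with a change elsewhere on the shared core, since all three compounds differ only at this one place.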